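The source may report more compounds than this note shows. Statements on the series, on what has been measured and on what is new or still open speak of the compounds shown alone.

Working notes on the series, read in a functional assay on SK-BR-3 cells (Homo sapiens) for antiproliferative activity, read by MTT assay, with a stated time of 72 h; a higher number here means a weaker inhibitor, a lower number a stronger inhibitor. Compound 2 `C/C=C1/[C@H](O[C@@H]2O[C@H](CO)[C@@H](O)[C@H](O)[C@H]2O)OC=C(C(=O)OC)[C@H]1CC(=O)OCCc1ccc2c(c1)OCCO2` gives > 20000 nM, which is a limit and not a number. Compound 1 `C/C=C1/[C@H](O[C@@H]2O[C@H](CO)[C@@H](O)[C@H](O)[C@H]2O)OC=C(C(=O)OC)[C@H]1CC(=O)NCCC` gives > 20000 nM, also a limit. Compound 3 `C#CCOC(=O)C[C@@H]1C(C(=O)OC)=CO[C@@H](O[C@@H]2O[C@H](COC(C)=O)[C@@H](OC(C)=O)[C@H](OC(C)=O)[C@H]2OC(C)=O)/C1=C/C` gives > 15000 nM, again a limit. Among the measured compounds shown here, no measured compound yields a number, so compound 2 cannot be ranked against the other two, and no measured pair differs in one place.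

Compound 4 `C/C=C1/[C@H](O[C@@H]2O[C@H](CO)[C@@H](O)[C@H](O)[C@H]2O)OC=C(C(=O)OC)[C@H]1CC(=O)OCCCc1ccc(OC)c(OC)c1` is still unmeasured. Its change from compound 2 is 3,4-dimethoxybenzyl in place of 2,3-dihydro-1,4-benzodioxin-6-yl on a saturated chain carbon, two bonds along the chain from an oxygen next to a carbonyl group.

For the measured compounds named here, the only anchor for this change is compound 2 with its limit of > 20000 nM. The estimated step that the limit leaves unreadable from compound 2 to compound 4 is expected to stay within the scatter in this assay, with no direction claimed. For compound 4 the expected value is 25000 nM, with an estimated range of 10000 nM to 60000 nM, and another report as a limit is the likelier outcome.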

Compound 4, half-maximal inhibitory concentration: > 20000 nM
Compound 4 was reported as a limit (the forecaster's own chance of this, stated with the estimate: 80%); the middle value lies beyond the limit too.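

In this assay compound 4 gives > 20000 nM, a limit and not a number. Among the compounds shown here, compound 2 is also reported as a limit, so no step between compound 2 and compound 4 can be read. The compounds shown leave open what half-maximal inhibitory concentration any of them has, and whether the change from 2,3-dihydro-1,4-benzodioxin-6-yl to 3,4-dimethoxybenzyl alters it.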